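This account rests on a few compounds, and the source may have more. Where it says the series, first, only, none or still open, it means among the compounds named here.

Compound 1 `Cc1cccc(C)c1NC(=O)Nc1ccncc1`, compound 2 `O=C(Nc1ccncc1)Nc1c(Cl)cccc1Cl` and compound 3 `Cc1cccc(C)c1NC(=O)Nc1cccnc1` have been tested in a functional assay on the whole organism with Mus musculus as the target, in the maximal electroshock model, with a stated time of 30 min (a higher number here means that more compound is needed for the effect, a lower number that less compound is needed), while compound 4 `O=C(Nc1cccnc1)Nc1c(Cl)cccc1Cl` is still to be measured. In this assay compound 1 gives 30 mg/kg, compound 2 gives 100 mg/kg and compound 3 gives 100 mg/kg; the values of compound 2 and compound 3 lie within the scatter of each other. The change from compound 1 to compound 3 is pyridin-3-yl in place of pyridin-4-yl on an amide-type nitrogen, and it brought a 3.3-fold higher number from compound 1 to compound 3 (0.52 log units; beyond the scatter). The same change, (pyridin-3-yl in place of pyridin-4-yl on an amide-type nitrogen), takes compound 2 to compound 4, at a place that is described in the same words for both pairs. How the core of compound 1 differs from the core of compound 2 is not broken down here. Because compound 2 already stands at 100 mg/kg and the earlier step was a 3.3-fold higher number from compound 1 to compound 3 (0.52 log units; beyond the scatter), compound 4 is expected to need a higher dose, with a step of a 3.0-fold higher number from compound 2 to compound 4 (0.48 log units; beyond the scatter), close in size to the earlier one. Compound 4 is therefore estimated at 300 mg/kg, most likely between 100 mg/kg and 600 mg/kg.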

Compound 4, minimum effective dose: > 300 mg/kg
Compound 4 gave a limit, no number (the forecaster's own chance of this, stated with the estimate: 30%); the middle value lies on the limit itself.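

In this assay compound 4 gives > 300 mg/kg, which is a limit of the assay and not a number. Pyridin-3-yl in place of pyridin-4-yl on an amide-type nitrogen gave an at least 3.0-fold higher number from compound 2 to compound 4 (0.47 log units; beyond the scatter), so in these two pairs the direction of the change seen on the core of compound 1 also holds on the core of compound 2, though two pairs show no general rule for the series. Whether the size of the step carries over from one core to the other is not shown: the same change on two cores in this assay, a 3.3-fold higher number (0.52 log units; beyond the scatter) from compound 1 to compound 3 and an at least 3.0-fold higher number (0.47 log units; beyond the scatter) from compound 2 to compound 4; the limit leaves it open whether they differ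

The compounds shown carry only pyridin-4-yl or pyridin-3-yl on the amide-type nitrogen, which leaves open how a plain phenyl group would stand in this assay. They also leave open whether the same change would act in the same direction on a core carrying methoxy or trifluoromethyl groups instead of the methyl or chloro groups present here.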